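The source may report more compounds than this note shows. Statements on the series, on what has been measured and on what is new or still open speak of the compounds shown alone.

Compound 1, `CCCSc1nnc(Cc2ccc(Cl)cc2Cl)o1`, in a functional assay on BHK-21 cells (Mesocricetus auratus) for cytotoxicity, with a stated time of 5 days (a lower number here means that less compound is tolerated, a higher number that more compound is tolerated), gives > 50000 nM, a limit of the assay.
Compound 2, `O=[N+]([O-])c1cccc(OCc2nnc(SCCCCl)o2)c1`, in this assay gives > 50000 nM, likewise a limit of the assay.

Going by the values given here, both measurements fall on (the limit of > 50000 nM in this assay, at which 2 of the 2 values shown sit), so compound 2 stands at the limit together with the only other compound, and no number separates them. Compound 3, `CCCSc1nnc(COc2cccc([N+](=O)[O-])c2)o1`, differs from compound 2 by hydrogen in place of chloro on a saturated chain carbon, three bonds along the chain from a sulfur. With no measured step available and only limits shown, the expected change is a step that the limit leaves unreadable from compound 2 to compound 3, none beyond the scatter. Compound 3 is therefore expected to give 60000 nM in this assay, within 20000 nM to 200000 nM, most likely again reported only as a limit.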

Compound 3, half-maximal cytotoxic concentration: > 50000 nM
Compound 3: a limit, no number (the forecaster's own chance of this, stated with the estimate: 85%); the middle value lies beyond the limit too.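

Going by these compounds alone, compound 2 and compound 3 both stand at a limit of the assay, so no step between them can be read: the limit of > 50000 nM in this assay, at which 3 of the 3 values shown sit.
The compounds shown leave open whether 3-chloropropyl to propyl changes anything in this assay at all, and what concentration any of them would actually tolerate.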